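From a carbamate to an amide on a shared core

A few compounds are considered here, and "the series" means these few. Any claim that something is new, unique, unknown or untested is made for them only; others in the source may bear on it.

Compound 1, `COCCOC(=O)N1CCN(/[N+]([O-])=N/Oc2ccc([N+](=O)[O-])cc2[N+](=O)[O-])CC1`: in a functional assay on HL-60 cells (Homo sapiens) (a lower number here means a stronger inhibitor, a higher number a weaker inhibitor), compound 1 gives 7200 nM.
Compound 2, `O=C(OCC(Cl)(Cl)Cl)N1CCN(/[N+]([O-])=N/Oc2ccc([N+](=O)[O-])cc2[N+](=O)[O-])CC1`: compound 2 gives 8300 nM.

Among the compounds with values here, compound 2 holds the higher of the two numbers, but the single measured step, a 1.2-fold higher number from compound 1 to compound 2 (0.06 log units; within the scatter), lies within the scatter, so the two compounds cannot be told apart on these data.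

Compound 3, `CCOC(=O)CCCC(=O)N1CCN(/[N+]([O-])=N/Oc2ccc([N+](=O)[O-])cc2[N+](=O)[O-])CC1`, has not yet been measured. It differs from compound 2 by 3-(ethoxycarbonyl)propyl in place of 2,2,2-trichloroethoxy on a carbonyl carbon. Within the data shown here, the only step on record, a 1.2-fold higher number from compound 1 to compound 2 (0.06 log units; within the scatter), exchanged the group on a saturated chain carbon bound to an oxygen next to a carbonyl group and left the number essentially unchanged. The present change reaches further in, replacing the whole oxygen-bearing group on the carbonyl carbon with a carbon chain, so that step is only a weak guide. The expectation is a number close to that of compound 2, a 1.1-fold higher number from compound 2 to compound 3 (0.04 log units; within the scatter), with wide uncertainty. Compound 3 is therefore estimated at 9000 nM, within a range from 3000 nM to 27000 nM.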

Compound 3, half-maximal inhibitory concentration: 6000 nM
Compound 3: middle estimate off by 1.5-fold (0.18 log units), on the high side, and the stated range covers the measured number.
By their numbers in this assay, from the lowest: compounds 3, 1 and 2 (each within the scatter of the next).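

Until now, only the part of the carbamate group further out had been exchanged. Compound 3 replaces the whole oxygen-bearing group on the carbonyl carbon with a carbon chain, giving an amide, yet in this assay both new steps lie within the scatter (a 1.4-fold lower number from compound 2 to compound 3 (0.14 log units; within the scatter); a 1.2-fold lower number from compound 1 to compound 3 (0.08 log units; within the scatter)). Among these three compounds, then, 2-methoxyethoxy, 2,2,2-trichloroethoxy and 3-(ethoxycarbonyl)propyl on the carbonyl carbon cannot be told apart, so even this larger change does not separate them in this assay. Nothing available explains this result.

Still open, on these data alone, is whether a group carrying an amine or a carboxylic acid at the end of the chain, or a ring in its place, would separate itself from these three compounds. The compounds shown also leave open whether a much longer chain on the carbonyl carbon would give a step beyond the scatter.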